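The source may report more compounds than this note shows. Statements on the series, on what has been measured and on what is new or still open speak of the compounds shown alone.

Measured in an ADME assay on Vero cells (Chlorocebus sabaeus) for cytotoxicity, read by MTT assay; on this read-out lower numbers stand for higher toxicity in this test and higher numbers for lower toxicity in this test:
- compound 1 `Cn1nc(C(F)(F)F)cc1C(=O)Nc1ccc(S(=O)(=O)N2CCC(C(F)(F)F)CC2)cc1`: 159000 nM
- compound 2 `Cn1nc(C(F)(F)F)cc1C(=O)Nc1ccc(S(=O)(=O)OC2CCCCC2)cc1`: > 300000 nM, a limit
- compound 3 `Cn1nc(C(F)(F)F)cc1C(=O)Nc1ccc(S(=O)(=O)N2CCOCC2)cc1`: > 300000 nM, a limit

Compound 3 has no number, only the limit > 300000 nM. Compound 2 shares that limit, so the series stands at the limit of > 300000 nM in this assay, at which 2 of the 3 values shown sit.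

Compound 4 `Cn1nc(C(F)(F)F)cc1C(=O)Nc1ccc(S(=O)(=O)N2CCCC(C(=O)O)C2)cc1` carries 3-carboxypiperidin-1-yl in place of morpholin-4-yl on a sulfonyl sulfur. For the measured compounds named here, no measured compound carries this group, so the evidence is indirect.

The relevant steps are changes at the same sulfonyl sulfur. The first is an at least 1.8-fold higher number from compound 1 to compound 3 (0.27 log units; that floor lies within the scatter). The second is an at least 1.8-fold higher number from compound 1 to compound 2 (0.27 log units; that floor lies within the scatter). Both are floors rather than sizes, and both lie within the scatter. The third, a step that the two limits leave unreadable from compound 2 to compound 3, cannot be read.

Among the measured compounds, only compound 1 gives a number, 159000 nM. The change to compound 4 is therefore not expected to produce a step beyond the scatter in this assay, and no direction is expected. The estimated step is a number no higher from compound 3 to compound 4 (the limit leaves the size open). A further limit is the most likely report for this compound. For compound 4 the expected value is 300000 nM, with an estimated range from 160000 nM to 500000 nM.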

Compound 4, half-maximal cytotoxic concentration: > 300000 nM
Compound 4: no number, only a limit; the forecaster's own chance of this, stated with the estimate: 70%; the middle value sits exactly at the limit.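

In this assay, for the compounds shown here, compound 4 gives > 300000 nM, which is a limit and not a number; this is the first group at the sulfonyl sulfur that brings a hydrogen-bond donor, and it too gives no measurable value. Against the only compound with a number, the result is an at least 1.8-fold higher number from compound 1 to compound 4 (0.27 log units; that floor lies within the scatter), so this comparison shows no step beyond the scatter. The steps from compound 2 and compound 3 to compound 4 cannot be read, and the new limit extends the pattern seen with compound 2 and compound 3, with compound 1 the one compound that goes against it: the limit of > 300000 nM in this assay, at which 3 of the 4 values shown sit.

From the compounds shown here alone, how far compound 2, compound 3 and compound 4 lie from one another stays open, as does whether any of them differs from compound 1 by more than the scatter. Also open, going by these compounds, is whether an amine or a longer chain ending in a carboxylic acid in place of 3-carboxypiperidin-1-yl on the sulfonyl sulfur would give a number in this assay rather than another limit.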